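The source may hold more compounds than are shown below. What is called first, only, known or untested is meant among the compounds shown, and "the series" means these compounds.

Compound 1, `CC1(C)Cc2c(sc(NC(=O)c3ccccc3O)c2C(N)=O)CO1`, gives 490 nM in an assay on cells for positive allosteric modulation of Cystic fibrosis transmembrane conductance regulator variant G551D (Homo sapiens), with stated times of 10 min and 2 min, in the presence of a further agent that is not named here; on this read-out lower numbers stand for an effect already at smaller amounts and higher numbers for an effect only at larger amounts of compound.
Compound 2, `CC1Cc2c(sc(NC(=O)c3ccccc3O)c2C(N)=O)C(C)O1`, gives 236 nM in this assay.
Compound 3, `CC1(C)Cc2c(sc(NC(=O)c3ccccc3O)c2C(N)=O)C(C)(C)O1`, gives 162 nM in this assay.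

All three share one core and the same amide-linked 2-hydroxyphenyl group; they differ only in the methyl groups on the saturated ring of the core. Compound 3 shows the lowest number of the three. The number for compound 2 lies close to it, within the usual scatter, so the two cannot be told apart; the number for compound 1 lies beyond the scatter, so compound 1 acts only at larger amounts than compound 3.

Compound 4, `CC1(C)Cc2c(sc(NC(=O)C3(CO)CC3)c2C(N)=O)C(C)(C)O1`, keeps the core of compound 3 with all its methyl groups and changes the amide partner: 1-(hydroxymethyl)cyclopropyl in place of 2-hydroxyphenyl on a carbonyl carbon. No measured pair among these compounds shows a change of this kind, so there is nothing in the data to gauge it against. The change is large relative to the methyl shifts seen so far, and a step beyond the scatter, towards a higher number, is expected; the estimated step from a 5.6-fold higher number from compound 3 to compound 4 (0.74 log units; beyond the scatter) carries wide uncertainty. Compound 4 is therefore expected to give about 900 nM in this assay, within a range from 150 nM to 6000 nM.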

Compound 4, half-maximal effective concentration: 1320 nM
Beside the measured number, compound 4's estimate is 1.5-fold (0.17 log units) below it; the range from low to high includes it.
By their numbers in this assay, from the lowest: compounds 3 and 2 (each within the scatter of the next); then compound 1; then compound 4.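

In this assay, the change of amide partner on a carbonyl carbon, 1-(hydroxymethyl)cyclopropyl in place of 2-hydroxyphenyl, gives an 8.1-fold higher number from compound 3 to compound 4 (0.91 log units; beyond the scatter). Among these compounds, the earlier compounds varied only the methyl groups on the saturated ring of the core, so this is the first sign that the amide partner also matters to the number, and this single step is larger than the gap among compounds 1, 2 and 3. The two groups have equal hydrogen-bond donor and acceptor counts, so those counts do not separate them, and nothing measured here says what does.

This single pair cannot show which feature of 2-hydroxyphenyl matters: its six-membered aromatic ring, its hydroxyl group or the way the two are combined. From the compounds shown here alone, a plain phenyl, a 2-aminophenyl or a cyclopropyl carrying a carboxylic acid on the same carbonyl carbon would help separate these, and it remains open whether 1-(hydroxymethyl)cyclopropyl gives a similar step on the cores of compound 1 and compound 2.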